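From carboxymethyl to 1-carboxy-1-methylethyl on compound 1

A few compounds are considered here, and "the series" means these few. Any claim that something is new, unique, unknown or untested is made for them only; others in the source may bear on it.

Among the measured compounds shown here, in a physicochemical assay for lipophilicity, read by HPLC, at pH 7.4 (on this read-out higher numbers stand for higher lipophilicity and lower numbers for lower lipophilicity), compound 1 (`O=C(O)COc1ccc([C@H]2CC[C@]3(CC2)OOC2(O3)C3CC4CC(C3)CC2C4)cc1`) gives 2.9, the higher of the two numbers so far, while compound 2 (`O=C(O)COc1ccc([C@H]2CC[C@]3(CC2)OOC2(O3)C3CC4CC(C3)CC2C4)cc1C(=O)O`) gives 1.9. Compound 3 (`CC(C)(Oc1ccc([C@H]2CC[C@]3(CC2)OOC2(O3)C3CC4CC(C3)CC2C4)cc1)C(=O)O`) keeps the core of compound 1 and changes one group: 1-carboxy-1-methylethyl in place of carboxymethyl on an oxygen on an aromatic ring. For the measured compounds named here, the only measured step, a number 1.00 log units lower from compound 1 to compound 2 (beyond the scatter), is a different change, carboxy in place of hydrogen on an aromatic carbon, so it offers only a rough sense of scale. Here the entering group differs from the leaving one only in its carbon count, so a modest rise is expected, an estimated a number 0.50 log units higher from compound 1 to compound 3 (beyond the scatter). The estimate for compound 3 is 3.4, with an expected range from 2.9 to 3.9.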

Compound 3, distribution coefficient: 3.1
The estimate for compound 3 lay 0.30 log units above the measured number, within the range that was stated.
By their numbers in this assay, from the lowest: compound 2; then compounds 1 and 3 (each within the scatter of the next).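

Placing 1-carboxy-1-methylethyl in place of carboxymethyl on an oxygen on an aromatic ring gives a number 0.20 log units higher from compound 1 to compound 3 (within the scatter) in this assay and so leaves the two compounds indistinguishable on this read-out. The larger group at this position therefore makes no measurable difference here, whereas adding carboxy on an aromatic carbon gave a number 1.00 log units lower from compound 1 to compound 2 (beyond the scatter) and was a clear shift. Nothing available explains this result.
On these data alone, whether a longer chain on that oxygen, or an amine in place of the carboxylic acid, would move the number remains open.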